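Benzimidazole biphenyl series: terminal ring swap on the unmethylated core

The source may report more compounds than this note shows. Statements on the series, on what has been measured and on what is new or still open speak of the compounds shown alone.

Of the compounds shown here, three have been measured. Compound 1 `Cc1ccc2[nH]c(-c3ccc(-c4ccc(-c5cccc(Cl)c5)cc4)cc3)nc2c1` gives 1210 nM in a functional assay on MCF7 cells (Homo sapiens) for inhibition, read by sulforhodamine B assay; a higher number here means a weaker inhibitor of growth, a lower number a stronger inhibitor of growth. Compound 2 `COc1ccc(-c2ccc(-c3ccc(-c4nc5cc(C)ccc5[nH]4)cc3)cc2)cc1OC` shares its core and differs only at the terminal ring, (3,4-dimethoxyphenyl in place of 3-chlorophenyl on an aromatic carbon); in this assay compound 2 gives 190 nM, which amounts to a 6.4-fold lower number from compound 1 to compound 2 (0.80 log units; beyond the scatter). Compound 3 `Clc1cccc(-c2ccc(-c3ccc(-c4nc5ccccc5[nH]4)cc3)cc2)c1` carries the same terminal ring as compound 1 but a different core; the two cores differ by hydrogen in place of methyl on an aromatic carbon, and compound 3 gives 36300 nM in this assay, a 30-fold higher number from compound 1 to compound 3 (1.48 log units; beyond the scatter). Compound 3 thus stands highest of the three measured numbers, and compound 2 lies furthest below it.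

Compound 4 `COc1ccc(-c2ccc(-c3ccc(-c4nc5ccccc5[nH]4)cc3)cc2)cc1OC` is not yet measured. It is related to compound 3 by 3,4-dimethoxyphenyl in place of 3-chlorophenyl on an aromatic carbon, the same change that separates compound 2 from compound 1, made on the core of compound 3 rather than on that of compound 1. The place of the change reads identically in both pairs. Within the data shown here, the only evidence for the size of this step is the single pair compound 1 to compound 2, so whether the same size carries over to the unmethylated core is untested.

Among the measured compounds shown here, the expectation is that compound 4 improves on compound 3 by roughly the step seen from compound 1 to compound 2, that is a 6.1-fold lower number from compound 3 to compound 4 (0.78 log units; beyond the scatter) in this assay, because the pair a 6.4-fold lower number from compound 1 to compound 2 (0.80 log units; beyond the scatter) is the only measured instance of this change. On that basis compound 4 is estimated at 6000 nM in this assay, with a range from 1500 nM to 25000 nM reflecting that the change has been seen once only.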

Compound 4, concentration for 50% growth inhibition: 7600 nM
Beside the measured number, compound 4's estimate is 1.3-fold (0.10 log units) below it; low and high end bracket the measured number.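

On the core of compound 3, 3,4-dimethoxyphenyl in place of 3-chlorophenyl gives in this assay a 4.8-fold lower number from compound 3 to compound 4 (0.68 log units; beyond the scatter) and so carries over to the second core at a size matching the earlier step: the same change on two cores in this assay, a 6.4-fold lower number (0.80 log units; beyond the scatter) from compound 1 to compound 2 and a 4.8-fold lower number (0.68 log units; beyond the scatter) from compound 3 to compound 4, 1.3-fold (0.12 log units) apart, within the scatter of two such steps.
Read the other way, hydrogen in place of methyl on an aromatic carbon gives a 40-fold higher number from compound 2 to compound 4 (1.60 log units; beyond the scatter) with 3,4-dimethoxyphenyl as the terminal ring, and this step also matches its earlier counterpart: the same change on two cores in this assay, a 30-fold higher number (1.48 log units; beyond the scatter) from compound 1 to compound 3 and a 40-fold higher number (1.60 log units; beyond the scatter) from compound 2 to compound 4, 1.3-fold (0.12 log units) apart, within the scatter of two such steps.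
Within these four compounds the two changes therefore behave as independent steps, but this rests on only two cores and two terminal rings in a single assay, and it neither explains either step nor shows that the same sizes would hold on any other core.

As far as these compounds go, it remains open whether both methoxy groups are needed for the terminal-ring step, or whether a single methoxy group on that ring would give a step of similar size. From the compounds shown here alone, it is also open whether a carboxylic acid or an amine on the terminal ring, or an ethyl group in place of the methyl on the core, would carry over between cores in the same way.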